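From compound 2 to compound 4: adding a phenoxy

This account rests on a few compounds, and the source may have more. Where it says the series, first, only, none or still open, it means among the compounds named here.

In an ADME assay on MT4 cells (Homo sapiens) for cytotoxicity, read by MTT assay, with a stated time of 96 h (on this read-out lower numbers stand for higher toxicity in this test and higher numbers for lower toxicity in this test), compound 2 `NS(=O)(=O)c1ccc(N2N=C(c3ccccc3)CC2c2ccccc2Cl)cc1` gives 44000 nM and stands within the scatter of both other measured compounds. Compound 1 `NS(=O)(=O)c1ccc(N2N=C(c3ccccc3)CC2c2ccccc2F)cc1` gives 42000 nM in the same test. Compound 4 `NS(=O)(=O)c1ccc(N2N=C(c3ccc(Oc4ccccc4)cc3)CC2c2ccccc2Cl)cc1` differs from compound 2 by one change, phenoxy in place of hydrogen on an aromatic carbon. Going by the values given here, the only measured step, a 1.0-fold higher number from compound 1 to compound 2 (0.02 log units; within the scatter), lies within the scatter and does not involve phenoxy. Compound 3 `Cc1ccc(C2CC(c3ccc(OCc4ccccc4)cc3)=NN2c2ccc(S(N)(=O)=O)cc2)cc1` carries a benzyloxy group and gives 35000 nM, which hints at no large shift. In this assay the expected step is a 1.4-fold lower number from compound 2 to compound 4 (0.14 log units; within the scatter), so nothing beyond the scatter is expected. For compound 4 the estimate is 32000 nM, with an expected range from 14000 nM to 70000 nM.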

Compound 4, half-maximal cytotoxic concentration: 40000 nM
For compound 4 the middle estimate is 1.3-fold (0.10 log units) below the measured one; low and high end bracket the measured number.
By their numbers in this assay, from the lowest: compounds 3, 4, 1 and 2 (each within the scatter of the next).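

In this assay the change from hydrogen to phenoxy, on an aromatic carbon para to a large group, gives a 1.1-fold lower number from compound 2 to compound 4 (0.04 log units; within the scatter) and so stays within the scatter. For this one pair, then, a group of 7 heavy atoms with its own aromatic ring can sit at this position without a clear shift in the read-out. Nothing measured here explains this result. From the compounds shown here alone, whether an amine or a carboxylic acid at the same position would also stay within the scatter remains open. So does the outcome for a smaller group such as methoxy.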